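Chloro added to the fluorophenyl ring: expectation for compound 4

The source may report more compounds than this note shows. Statements on the series, on what has been measured and on what is new or still open speak of the compounds shown alone.

Measured so far in a functional assay on NCI-H460 cells (Homo sapiens) for antiproliferative activity, read by MTT assay, with a stated time of 72 h; a higher number here means a weaker inhibitor, a lower number a stronger inhibitor:
- compound 1 `O=C(Nc1ccc(Oc2ccnc3[nH]ccc23)cc1)c1cc2cccnc2n(-c2ccc(F)cc2)c1=O`: 190 nM
- compound 2 `COc1ccc(-n2c(=O)c(C(=O)Nc3ccc(Oc4ccnc5[nH]ccc45)cc3)cc3cccnc32)cc1`: 960 nM
- compound 3 `O=C(Nc1ccc(Oc2ccnc3[nH]ccc23)c(F)c1)c1cc2cccnc2n(-c2ccc(F)cc2)c1=O`: 87 nM

Compound 3 gives the lowest number of the three in this assay; its steps to compound 1 and to compound 2 are both beyond the scatter, so it is the strongest inhibitor of this set. Compound 4 `O=C(Nc1ccc(Oc2ccnc3[nH]ccc23)c(F)c1)c1cc2cccnc2n(-c2ccc(F)c(Cl)c2)c1=O` differs from compound 3 in one place: chloro in place of hydrogen on an aromatic carbon.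

Among the compounds with values here, no measured pair shows exactly this change. Within the data shown here, two steps bear on it indirectly. The step of a 5.1-fold higher number from compound 1 to compound 2 (0.70 log units; beyond the scatter) shows that the ring carrying the fluoro group is sensitive to what is put on it, and that a larger group there in place of fluoro weakened inhibition. The step of a 2.2-fold lower number from compound 1 to compound 3 (0.34 log units; beyond the scatter) shows that adding a halogen to an aromatic carbon elsewhere in the shared core strengthened inhibition. Here the fluoro group stays and a chloro group is added alongside it, a change with no direct precedent in the set.

With compound 3 at 87 nM, compound 4 is expected to land close to it, with a step of about a 1.2-fold lower number from compound 3 to compound 4 (0.09 log units; within the scatter), near the scatter and without a firm direction. The estimate for compound 4 in this assay is 70 nM, with a range from 25 nM to 250 nM.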

Compound 4, half-maximal inhibitory concentration: 1050 nM
For compound 4 the middle estimate is 15-fold (1.18 log units) below the measured one; the whole stated range lies below it.
By their numbers in this assay, from the lowest: compound 3; then compound 1; then compounds 2 and 4 (each within the scatter of the next).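

In this assay, the change from 4-fluorophenyl to 3-chloro-4-fluorophenyl gives a 12-fold higher number from compound 3 to compound 4 (1.08 log units; beyond the scatter), so a single added chlorine ortho to a fluoro group is enough to cause a large loss of inhibition, even though the fluoro group itself stays in place. Until now, the sensitivity of this ring rested only on replacing fluoro with methoxy, a 5.1-fold higher number from compound 1 to compound 2 (0.70 log units; beyond the scatter), and the one halogen added to an aromatic carbon had lowered the number, a 2.2-fold lower number from compound 1 to compound 3 (0.34 log units; beyond the scatter), so adding a halogen clearly does not have the same outcome everywhere in this series: the two additions, on different rings, go in opposite directions. Nothing available on these compounds accounts for the loss.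

Going by these compounds, it remains open whether the loss is specific to chloro or whether another group on the same carbon, such as methyl, an amine or a second fluoro, would cost as much. On these data alone, it is also open whether the 3-chloro-4-fluorophenyl ring would give a step of similar size on compound 1, which lacks the added fluoro of compound 3.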